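This account rests on a few compounds, and the source may have more. Where it says the series, first, only, none or still open, it means among the compounds named here.

In a functional assay on MDA-MB-231 cells (Homo sapiens) for inhibition, read by sulforhodamine B assay, with a stated time of 48 h (a higher number here means a weaker inhibitor, a lower number a stronger inhibitor), compound 1 `COc1ccc(C(c2ccc(OC(C)CN(C)C)cc2)c2cccc3ccccc23)c(OC)c1OC` gives 4340 nM. Compound 2 `COc1ccc(C(O)(Cc2ccc(C)cc2)c2cccc3ccccc23)c(OC)c1OC` has no exact place on this scale. For compound 2 the assay reports only a limit, > 20000 nM, as the limit of > 20000 nM in this assay, at which 1 of the 2 values shown sits, records. Compound 3 `COc1ccc(C(O)(Cc2ccc(F)cc2)c2cccc3ccccc23)c(OC)c1OC` departs from compound 2 at a single place: fluoro in place of methyl on an aromatic carbon. This puts fluoro in place of methyl on an aromatic carbon, turning 4-methylbenzyl into 4-fluorobenzyl. Within the data shown here, no measured pair in this small set shows what such an exchange does in this assay, so the expectation stays modest, with no change beyond the scatter and no favoured direction. The expected size of the step is a step that the limit leaves unreadable from compound 2 to compound 3. The estimate for compound 3 is 22000 nM, with an expected range of 9000 nM to 50000 nM. It may well be that the assay again returns only a limit.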

Compound 3, half-maximal inhibitory concentration: 5440 nM
Estimate against measurement, compound 3: 4.0-fold (0.61 log units) above, and the stated range ends above it.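

Turning 4-methylbenzyl into 4-fluorobenzyl gives the first readable effect at this place on an aromatic carbon: in this assay, the exchange brings an at least 3.6-fold lower number from compound 2 to compound 3 (0.56 log units; beyond the scatter). Compound 2 has only a limit and no exact number: the limit of > 20000 nM in this assay, at which 1 of the 3 values shown sits. Compound 3, by contrast, has an exact value, so exchanging a single heavy atom at this place, with no ring, hydrogen-bond donor or hydrogen-bond acceptor entering or leaving, is enough to carry the read-out beyond the scatter.

Going by these compounds, the full size of the step remains open, since only its lower bound can be read. On these data alone, it also remains open whether the effect is particular to fluoro, or whether chloro, trifluoromethyl or methoxy at the same place would give a similar number in this assay.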